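Trading a 4-cyanobenzyl for a 3-(trifluoromethyl)benzyl

A few compounds are considered here, and "the series" means these few. Any claim that something is new, unique, unknown or untested is made for them only; others in the source may bear on it.

Three compounds share one core and differ only in the group on a saturated chain carbon bound to an oxygen on an aromatic ring. In a functional assay on U-251 cells (Homo sapiens) for antiproliferative activity, read by MTT assay, with a stated time of 24 h (a lower number here means a stronger inhibitor, a higher number a weaker inhibitor), compound 1 `COc1cc(OC)c(-c2coc3cc(OCc4ccc(Br)cc4)ccc3c2=O)cc1OC` gives 10000 nM, compound 2 `COc1cc(OC)c(-c2coc3cc(OCc4ccccc4C)ccc3c2=O)cc1OC` gives 2000 nM, and compound 3 `COc1cc(OC)c(-c2coc3cc(OCc4ccc(C#N)cc4)ccc3c2=O)cc1OC` gives 6180 nM. Compound 3 therefore holds the second highest number of the three: its nearest neighbour is compound 1, separated by a 1.6-fold lower number from compound 1 to compound 3 (0.21 log units; within the scatter), and its furthest is compound 2, separated by a 3.1-fold higher number from compound 2 to compound 3 (0.49 log units; beyond the scatter).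

Compound 4 `COc1cc(OC)c(-c2coc3cc(OCc4cccc(C(F)(F)F)c4)ccc3c2=O)cc1OC` now carries 3-(trifluoromethyl)phenyl in place of 4-cyanophenyl on a saturated chain carbon bound to an oxygen on an aromatic ring. Of the measured steps, the one that speaks to this change most directly is a 5.0-fold lower number from compound 1 to compound 2 (0.70 log units; beyond the scatter), which shows that replacing one substituted phenyl by another on this chain carbon can move the number noticeably, while a 1.6-fold lower number from compound 1 to compound 3 (0.21 log units; within the scatter) shows that a change of the group on the aromatic carbon alone left the number where it was. Among the compounds with values here, with no measured compound bearing a 3-(trifluoromethyl)phenyl, a modest move toward a lower number is expected, a 1.5-fold lower number from compound 3 to compound 4 (0.19 log units; within the scatter), without certainty about its size. Compound 4 is thus estimated at 4000 nM, within a range of 1500 nM to 12000 nM.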

Compound 4, half-maximal inhibitory concentration: > 10000 nM
Compound 4 was reported as a limit (the forecaster's own chance of this, stated with the estimate: 15%); middle value at least 2.5-fold (0.39 log units) from the limit.
By their numbers in this assay, from the lowest: compound 2; then compounds 3 and 1 (each within the scatter of the next).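

In this assay compound 4 gives > 10000 nM, which is a limit of the assay and not a number: the limit of > 10000 nM in this assay, at which 1 of the 4 values shown sits. Even so, the step from the 2-methylphenyl compound can be read, an at least 5.0-fold higher number from compound 2 to compound 4 (0.69 log units; beyond the scatter), and compound 2 now stands as the strongest of the four, with its steps to all three others printed as beyond the scatter. The step from the 4-cyanophenyl compound, an at least 1.6-fold higher number from compound 3 to compound 4 (0.20 log units; that floor lies within the scatter), has a floor within the scatter, so exchanging 4-cyanophenyl for 3-(trifluoromethyl)phenyl is not shown to make a real difference, and the remaining step, a number no lower from compound 1 to compound 4 (the limit leaves the size open), cannot be read for size.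

The compounds shown leave open how an unsubstituted phenyl, a 4-methylphenyl or a 2-(trifluoromethyl)phenyl would read on this chain carbon, so it remains unsettled whether the lower number of compound 2 goes with the methyl group itself or with its place on the ring. They also leave open how a phenyl carrying an amine or a carboxylic acid would read here.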